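Swapping sec-butyl for isobutyl in a second series

The source may hold more compounds than are shown below. What is called first, only, known or untested is meant among the compounds shown, and "the series" means these compounds.

In a functional assay on HeLa cells (Homo sapiens) for antiproliferative activity, read by MTT assay, with a stated time of 48 h (a higher number here means a weaker inhibitor, a lower number a stronger inhibitor), compound 1 `COC(=O)[C@H](CC(C)C)NC(=O)c1ccc(Oc2nc3ccccc3nc2C)cc1` gives 21600 nM. Compound 2 `CC[C@@H](C)[C@H](NC(=O)c1ccc(Oc2nc3ccccc3nc2C)cc1)C(=O)OC` reaches only a limit in this assay, > 50000 nM. Compound 2 differs from compound 1 by isobutyl in place of sec-butyl on a saturated chain carbon bound to an amide-type nitrogen and a carbonyl carbon, and that change gives an at least 2.3-fold lower number from compound 2 to compound 1 (0.36 log units; beyond the scatter), a step whose size rests on (the limit of > 50000 nM in this assay, at which 1 of the 3 values shown sits). Compound 3 `CC[C@@H](C)[C@H](NC(=O)c1ccc(Oc2nc3ccccc3nc2NC(C)(C)C)cc1)C(=O)O` gives 13400 nM in this assay; the difference between its core and that of compound 2 is not broken down here. Compound 4 `CC(C)C[C@H](NC(=O)c1ccc(Oc2nc3ccccc3nc2NC(C)(C)C)cc1)C(=O)O` is not yet measured and differs from compound 3 by isobutyl in place of sec-butyl on a saturated chain carbon bound to an amide-type nitrogen and a carbonyl carbon, the same change at the same place as before. Because the earlier pair gave an at least 2.3-fold lower number from compound 2 to compound 1 (0.36 log units; beyond the scatter), a drop of similar size is expected, a 2.2-fold lower number from compound 3 to compound 4 (0.35 log units; beyond the scatter). Compound 4 is therefore estimated at 6000 nM, probably between 2500 nM and 15000 nM.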

Compound 4, half-maximal inhibitory concentration: 39200 nM
Compound 4: middle estimate off by 6.5-fold (0.82 log units), on the low side; the measured number lies above the stated range.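

In this assay, the change gives a 2.9-fold higher number from compound 3 to compound 4 (0.47 log units; beyond the scatter), and set beside the earlier pair, it does not carry over from one core to the other: the same change on two cores in this assay, an at least 2.3-fold lower number (0.36 log units; beyond the scatter) from compound 2 to compound 1 and a 2.9-fold higher number (0.47 log units; beyond the scatter) from compound 3 to compound 4, at least 6.7-fold (0.83 log units) apart, beyond the scatter of two such steps

The earlier step gives only a minimum size, as it rests on a limit: the limit of > 50000 nM in this assay, at which 1 of the 4 values shown sits.

The two cores differ in more than one place, and these pairs do not show which of those differences reverses the step.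

Still open, from the compounds shown here alone, is how the step would run on a core pairing the methyl ester with the tert-butylamino group, or the carboxylic acid with the methyl group, which would separate those differences. Also open, going by these compounds, is whether a longer chain in place of isobutyl or sec-butyl would follow either direction.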